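The compounds below may be only part of what the source reports. "The series", "measured", "known", "first", "only" and "open" are said of these compounds alone.

Of the compounds shown here, three sharing one core have been measured in an ADME assay on HUVEC cells (Homo sapiens) for cytotoxicity, read by MTT assay, with a stated time of 24 h; a lower number here means that less compound is tolerated, a higher number that more compound is tolerated. Compound 1 `Fc1ccc(/C=C/c2nnc(-c3ccc4c(c3)OCCO4)o2)cc1` gives 325000 nM, compound 2 `Fc1ccccc1/C=C/c1nnc(-c2ccc3c(c2)OCCO3)o1` gives 402000 nM, and compound 3 `Clc1ccccc1/C=C/c1nnc(-c2ccc3c(c2)OCCO3)o1` gives 368000 nM. Compound 3 stands second highest of the three numbers, with compound 2 nearest and compound 1 furthest, and every step among the three lies within the scatter: a 1.2-fold higher number from compound 1 to compound 2 (0.09 log units; within the scatter), a 1.1-fold higher number from compound 1 to compound 3 (0.05 log units; within the scatter) and a 1.1-fold lower number from compound 2 to compound 3 (0.04 log units; within the scatter).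

Compound 4 `Cc1cccc(/C=C/c2nnc(-c3ccc4c(c3)OCCO4)o2)c1` has not yet been measured in this assay. It differs from compound 3 in one place: 3-methylphenyl in place of 2-chlorophenyl on a double-bonded chain carbon bound to a double-bonded chain carbon. Among the measured compounds shown here, the steps that bear on this change are the two in which the aryl group on the double-bonded chain carbon was exchanged, a 1.2-fold higher number from compound 1 to compound 2 (0.09 log units; within the scatter) and a 1.1-fold higher number from compound 1 to compound 3 (0.05 log units; within the scatter), and the one in which chloro replaced fluoro, a 1.1-fold lower number from compound 2 to compound 3 (0.04 log units; within the scatter); none of them moved the number beyond the scatter. The step expected for compound 4 is therefore a 1.0-fold higher number from compound 3 to compound 4 (0.00 log units; within the scatter), nothing beyond the scatter in either direction. The estimate for compound 4 in this assay is 370000 nM, with a range from 190000 nM to 720000 nM.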

Compound 4, half-maximal cytotoxic concentration: 201000 nM
Compound 4: middle estimate off by 1.8-fold (0.27 log units), on the high side; measured number inside the range.
By their numbers in this assay, from the lowest: compounds 4, 1, 3 and 2 (each within the scatter of the next).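

Replacing the halogen-bearing aryl groups with 3-methylphenyl gave the largest steps yet seen at this place in this assay (a 1.8-fold lower number from compound 3 to compound 4 (0.26 log units; within the scatter)), (a 2.0-fold lower number from compound 2 to compound 4 (0.30 log units; within the scatter)) and (a 1.6-fold lower number from compound 1 to compound 4 (0.21 log units; within the scatter)). All three still lie within the scatter, so a carbon-only 3-methylphenyl on a double-bonded chain carbon is not separated from the fluorophenyl and chlorophenyl groups, even though it carries no halogen. Nothing shown accounts for the size of these steps.

Compound 4 differs from each earlier compound in both the kind of ring substituent and its location on the ring, and the compounds shown cannot separate those two changes. On these data alone, whether an amine, a carboxylic acid or a longer chain on this aryl ring would move the number beyond the scatter remains open.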